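The source may report more compounds than this note shows. Statements on the series, on what has been measured and on what is new or still open speak of the compounds shown alone.

Compound 2 `CCC(C)/N=c1\c(O)c(O)\c1=N/c1ccc(C#N)cc1` and compound 1 `CC(C)C(C)/N=c1\c(O)c(O)\c1=N/c1ccc(C#N)cc1` share one core; in a functional assay for inhibition, with Rattus norvegicus as the target (a lower number here means a stronger inhibitor, a higher number a weaker inhibitor), compound 2 gives 2100 nM and compound 1 gives 1900 nM. The change between them, (methyl in place of hydrogen on a saturated chain carbon bound to two saturated chain carbons), made a step of a 1.1-fold lower number from compound 2 to compound 1 (0.04 log units; within the scatter). Compound 3 `C[C@@H](/N=c1\c(O)c(O)\c1=N/c1ccc(C#N)cc1)c1ccccc1` carries another core, the difference being (1-phenylethyl in place of sec-butyl on a double-bonded nitrogen); the step is a 38-fold lower number from compound 2 to compound 3 (1.57 log units; beyond the scatter), and against compound 1 it is a 34-fold lower number from compound 1 to compound 3 (1.53 log units; beyond the scatter). In this assay compound 3 gives 56 nM. Compound 4 `CC[C@@H](/N=c1\c(O)c(O)\c1=N/c1ccc(C#N)cc1)c1ccccc1` is not yet measured and differs from compound 3 by methyl in place of hydrogen on a saturated chain carbon, two bonds along the chain from an aromatic carbon and a double-bonded nitrogen. This is the same kind of change as that from compound 2 to compound 1, occurring in two pairs here, though there the place is a saturated chain carbon bound to two saturated chain carbons, whereas here it is a saturated chain carbon two bonds along the chain from an aromatic carbon and a double-bonded nitrogen. Because the earlier step was a 1.1-fold lower number from compound 2 to compound 1 (0.04 log units; within the scatter), the step for compound 4 is expected to be small, about a 1.3-fold higher number from compound 3 to compound 4 (0.10 log units; within the scatter). The estimate for compound 4 in this assay is 70 nM, between 25 nM and 200 nM.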

Compound 4, half-maximal inhibitory concentration: 22500 nM
Compound 4: middle estimate off by 320-fold (2.51 log units), on the low side; the whole stated range lies below it.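

In this assay, methyl in place of hydrogen on the core of compound 3 gives a 400-fold higher number from compound 3 to compound 4 (2.60 log units; beyond the scatter). The same change therefore does not carry over from one core to the other in this series: the same change on two cores in this assay, a 1.1-fold lower number (0.04 log units; within the scatter) from compound 2 to compound 1 and a 400-fold higher number (2.60 log units; beyond the scatter) from compound 3 to compound 4, 440-fold (2.65 log units) apart, beyond the scatter of two such steps. Within the data shown here, with only one pair on each core, this shows that the step on one core failed to predict the step on the other, but not what produces the gap or how the change would behave on any further core.

Still open, going by these compounds, is whether a longer chain, such as propyl, on the same saturated chain carbon would give a step like that of methyl. Also open, on these data alone, is how a hydroxyl or an amine would behave there.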